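Methyl branching at the ketone chain: notes on compounds 1 to 4

The source may report more compounds than this note shows. Statements on the series, on what has been measured and on what is new or still open speak of the compounds shown alone.

compound 1 `Cc1c(OCCCCOc2ccc(C(=O)C(C)C)c(O)c2C)cccc1C(=O)O`: 27.1%
compound 2 `CCC(=O)c1ccc(OCCCCOc2cccc(C(=O)O)c2C)c(C)c1O`: 16.3%
compound 3 `CCC(=O)c1ccc(OCCCCOc2ccc(F)c(C(=O)O)c2)c(C)c1O`: 18.4%

In an assay on HEK293 cells for positive allosteric modulation of metabotropic glutamate receptor 3 (Rattus norvegicus), read by thallium flux, with a stated time of 2.5 min (on this read-out higher numbers stand for larger maximal responses and lower numbers for smaller maximal responses), compound 1 gives 27.1%, compound 2 gives 16.3% and compound 3 gives 18.4%. Within the data shown here, the one measured pair that differs in a single place is compound 2 against compound 1, the change being (methyl in place of hydrogen on a saturated chain carbon bound to a carbonyl carbon and a saturated chain carbon); this gave a number 10.8 percentage points higher from compound 2 to compound 1 (beyond the scatter). How the core of compound 3 differs from that of compound 2 is not broken down here.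

Compound 4 `Cc1c(OCCCCOc2ccc(F)c(C(=O)O)c2)ccc(C(=O)C(C)C)c1O` has not been measured in this assay. It differs from compound 3 by methyl in place of hydrogen on a saturated chain carbon bound to a carbonyl carbon and a saturated chain carbon, the same change as the measured one, at the same kind of place. Because a number 10.8 percentage points higher from compound 2 to compound 1 (beyond the scatter), a step of a number 10.6 percentage points higher from compound 3 to compound 4 (beyond the scatter) is expected here as well. Compound 4 is therefore estimated at 29%, with 18% to 40% as the expected range.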

Compound 4, largest response reached (reported as percent of maximum), in percent of the reference or control that the assay uses: 31.3%
Beside the measured number, compound 4's estimate is 2.3 percentage points below it; the range from low to high includes it.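

The ethyl to isopropyl change gave a number 12.9 percentage points higher from compound 3 to compound 4 (beyond the scatter) in this assay. Set beside the earlier step, the two agree: the same change on two cores in this assay, a number 10.8 percentage points higher (beyond the scatter) from compound 2 to compound 1 and a number 12.9 percentage points higher (beyond the scatter) from compound 3 to compound 4, 2.1 percentage points apart, within the scatter of two such steps The methyl therefore kept the size of its step when carried from one core to the other, but two cores are a narrow base, and this says nothing about how the change would behave on any other core in the series.

The compounds shown leave open what a tert-butyl or cyclopropyl group in place of the isopropyl would give. They also leave open whether a tetrazole in place of the carboxylic acid would keep the step.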